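The compounds below may be only part of what the source reports. "The series", "measured", "known", "first", "only" and "open" are said of these compounds alone.

Working notes on the series. Compound 1 `O=S(=O)(NCCCNCc1ccccc1Cl)c1cc(C(F)(F)F)cc(C(F)(F)F)c1` is the reference for this step. In a functional assay on MIA PaCa-2 cells (Homo sapiens) for inhibition, read by MTT assay, with a stated time of 72 h (on this read-out higher numbers stand for weaker inhibition of growth and lower numbers for stronger inhibition of growth), compound 1 gives 11000 nM, which stands as the lowest of the three numbers in hand, though compound 2 `COc1ccc(S(=O)(=O)NCCCCCCNCc2ccc(Br)cc2)cc1` with 13000 nM and compound 3 `O=S(=O)(NCCCCCCNCc1ccc(Br)cc1)c1c(Cl)cccc1Cl` with 14700 nM both lie within the scatter of it, so no order among the three can be read. For the measured compounds named here, the only paired step among the measured compounds, a 1.1-fold higher number from compound 2 to compound 3 (0.05 log units; within the scatter), concerns the aryl on the sulfonyl sulfur and not the benzylic side, and it stays within the scatter.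

Compound 4 `O=S(=O)(NCCCNCc1ccc(Br)cc1)c1cc(C(F)(F)F)cc(C(F)(F)F)c1` differs from compound 1 at the benzylic end: 4-bromophenyl in place of 2-chlorophenyl on a saturated chain carbon bound to an amine nitrogen, that is, 2-chlorobenzyl becomes 4-bromobenzyl. Going by the values given here, no measured step probes this exchange directly; the 4-bromobenzyl group is present in compound 2 and compound 3, whose values sit within the scatter of compound 1. The expectation for compound 4 is therefore no step beyond the scatter, no change at the digits printed from compound 1 to compound 4 (within the scatter). Compound 4 is estimated at 11000 nM, with a range from 5000 nM to 25000 nM.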

Compound 4, concentration for 50% growth inhibition: 2300 nM
Beside the measured number, compound 4's estimate is 4.8-fold (0.68 log units) above it; measured number below the stated range.
By their numbers in this assay, from the lowest: compound 4; then compounds 1, 2 and 3 (each within the scatter of the next).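

In this assay, 4-bromobenzyl in place of 2-chlorobenzyl, on a saturated chain carbon bound to an amine nitrogen, gives a 4.8-fold lower number from compound 1 to compound 4 (0.68 log units; beyond the scatter). For the compounds shown here, this is the first step to lie beyond the scatter, and it shows that the benzylic end can move this read-out, whereas the one earlier paired step, at the aryl on the sulfonyl sulfur, did not. The exchange alters both the halogen and its place on the ring, and no data in hand bear on the origin of the step.

Whether the halogen or its place accounts for the step stays open, and 4-chlorobenzyl and 2-bromobenzyl on the same core would separate the two. Also open, going by these compounds, is whether the same exchange holds on a longer chain, or with a 4-methoxybenzyl or an unsubstituted benzyl group at this place.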